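Benzyl in place of 4-hydroxycyclohexyl on the aryl ether

The source may hold more compounds than are shown below. What is called first, only, known or untested is meant among the compounds shown, and "the series" means these compounds.

Compound 2 `O=C(NCCNS(=O)(=O)c1ccc(-c2ccccc2O[C@H]2CC[C@H](O)CC2)s1)Nc1cc(Cl)cc(Cl)c1` in a functional assay on HeLa cells (Homo sapiens) for inhibition, read by CCK-8 assay, with a stated time of 48 h (on this read-out higher numbers stand for weaker inhibition and lower numbers for stronger inhibition), gives > 20000 nM, which is a limit of the assay and not a number. Compound 2 therefore sits at the limit of > 20000 nM in this assay, at which 2 of the 3 values shown sit. Compound 3 `O=C(Nc1cccc([N+](=O)[O-])c1)N1CCN(S(=O)(=O)c2sccc2-c2ccccc2Oc2ccc(O)c(O)c2)CC1` in this assay gives > 20000 nM, again a limit. Compound 1 `COc1cccc(NC(=S)NCCNS(=O)(=O)c2ccc(-c3ccccc3Oc3ccc([N+](=O)[O-])cc3)s2)c1` in this assay gives > 50000 nM, a limit as well, so it stands at the limit of > 50000 nM in this assay, at which 1 of the 3 values shown sits. No compound shown reaches a measured number, and no step between measured compounds can be sized.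

Compound 4 `O=C(NCCNS(=O)(=O)c1ccc(-c2ccccc2OCc2ccccc2)s1)Nc1cc(Cl)cc(Cl)c1` differs from compound 2 by benzyl in place of 4-hydroxycyclohexyl on an oxygen on an aromatic ring. With every value shown a limit, the expected step is a step that the limit leaves unreadable from compound 2 to compound 4, none beyond the scatter, and compound 4 is expected most likely to remain at a limit. Compound 4 is estimated at 30000 nM, within 8000 nM to 100000 nM.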

Compound 4, half-maximal inhibitory concentration: > 20000 nM
Compound 4: no number, only a limit; the forecaster's own chance of this, stated with the estimate: 70%; the middle value does not contradict the limit.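

In this assay, for the compounds shown here, compound 4 gives > 20000 nM, a limit, and compound 2 also stands at a limit, so no step between the two can be read. The compounds shown leave open whether benzyl or 4-hydroxycyclohexyl changes inhibition at all.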